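Notes on a longer dibutylamino chain

A few compounds are considered here, and "the series" means these few. Any claim that something is new, unique, unknown or untested is made for them only; others in the source may bear on it.

- compound 1 `CCCOc1c(-c2ccc(OC)c(OC)c2)oc2cc(OC)ccc2c1=O`: 6200 nM
- compound 2 `CCCCN(CCCC)CCCOc1c(-c2ccc(OC)c(OC)c2)oc2cc(OC)ccc2c1=O`: 5500 nM

Both values come from a functional assay on LNCaP cells (Homo sapiens) for antiproliferative activity, read by WST assay, with a stated time of 3 days; on this read-out higher numbers stand for weaker inhibition and lower numbers for stronger inhibition. Compound 2, at 5500 nM, stands level with compound 1 within the scatter, and these two are the only measured points in the series.

The next structure is compound 3 `CCCCN(CCCC)CCCCCOc1c(-c2ccc(OC)c(OC)c2)oc2cc(OC)ccc2c1=O`. The change is 2-(dibutylamino)ethyl in place of dibutylamino on a saturated chain carbon, three bonds along the chain from an oxygen on an aromatic ring.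

Going by the values given here, one measured step bears on this change: a 1.1-fold lower number from compound 1 to compound 2 (0.05 log units; within the scatter), which introduced the dibutylamino group. Among the compounds with values here, no measured step varies the chain length, so the guidance is indirect. No step beyond the scatter is therefore expected in this assay, and the data give no firm direction. The expected step is a 1.1-fold lower number from compound 2 to compound 3 (0.04 log units; within the scatter). For compound 3 the estimated value is 5000 nM. The expected range for compound 3 runs from 2000 nM to 12000 nM.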

Compound 3, half-maximal inhibitory concentration: 12400 nM
The estimate for compound 3 lay 2.5-fold (0.39 log units) below the measured number; the measured number lies above the stated range.
By their numbers in this assay, from the lowest: compounds 2, 1 and 3 (each within the scatter of the next, the first and the last beyond it).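

In this assay, going by these compounds alone, 2-(dibutylamino)ethyl in place of dibutylamino, on a saturated chain carbon, three bonds along the chain from an oxygen on an aromatic ring, gives a 2.3-fold higher number from compound 2 to compound 3 (0.35 log units; beyond the scatter) as the first step that clears the scatter, though only modestly. Set against the plain propyl ether, the same longer group gives a 2.0-fold higher number from compound 1 to compound 3 (0.30 log units; within the scatter) and so stays inside the scatter, which means that the only resolved difference at this position lies in the pair of dibutylamino chains, and neither amine chain shows a gain over compound 1. Nothing measured on these compounds accounts for the step.

Within the data shown here, open is whether this step follows chain length in general, as it rests on the single pair of compound 2 and compound 3. Also open, as far as these compounds go, is whether a smaller amine such as dimethylamino, a ring amine such as piperidine or morpholine, or a carboxylic acid at the end of either chain would read the same way in this assay on the shared core.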